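A few compounds are considered here, and "the series" means these few. Any claim that something is new, unique, unknown or untested is made for them only; others in the source may bear on it.

Measured so far:
compound 2 `CCOc1ccc(-n2nncc2CN2C(=O)C3(C(C#N)=C(N)Oc4c(N)cc5nc6ccccc6nc5c43)c3ccccc32)cc1` – > 50000 nM
compound 1 `N#CC1=C(N)Oc2c(c3nc4ccccc4nc3c3ccccc23)C12C(=O)N(Cc1cnnn1-c1ccc(F)cc1)c1ccccc12` – > 50000 nM

In a functional assay on HCT-116 cells (Homo sapiens) for antiproliferative activity, read by MTT assay, with a stated time of 48 h (on this read-out higher numbers stand for weaker inhibition and lower numbers for stronger inhibition), compound 2 gives > 50000 nM, which is a limit of the assay rather than a number. Compound 1 likewise reaches only a limit, > 50000 nM, so both sit at the limit of > 50000 nM in this assay, at which 2 of the 2 values shown sit. Compound 3 `N#CC1=C(N)Oc2c(N)cc3nc4ccccc4nc3c2C12C(=O)N(Cc1cnnn1-c1ccc(F)c(Cl)c1)c1ccccc12` is yet to be measured; it differs from compound 2 by 3-chloro-4-fluorophenyl in place of 4-ethoxyphenyl on an aromatic nitrogen. With both neighbours at the limit, no step beyond the scatter is expected in this assay, in either direction. Compound 3 is therefore expected to give about 50000 nM, within 15000 nM to 150000 nM, most likely again as a limit. The step that this estimate means is expected to be a number no higher from compound 2 to compound 3 (the limit leaves the size open).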

Compound 3, half-maximal inhibitory concentration: > 50000 nM
Compound 3 was reported as a limit (the forecaster's own chance of this, stated with the estimate: 85%); the middle value sits exactly at the limit.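

In this assay, going by these compounds alone, compound 2 and compound 3 both reach only a limit, so no step between them can be read. The compounds shown leave open how 3-chloro-4-fluorophenyl and 4-ethoxyphenyl truly compare, and whether any close relative gives a measurable value.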